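A hydroxy ring swap on the sulfonyl sulfur

This account rests on a few compounds, and the source may have more. Where it says the series, first, only, none or still open, it means among the compounds named here.

In an ADME assay on HepG2 2.2.15 cells (Homo sapiens) for cytotoxicity, read by luminescence, with a stated time of 3 days (a lower number here means that less compound is tolerated, a higher number that more compound is tolerated), compound 1 (`COC1COCCN(S(=O)(=O)c2cc(C(=O)Nc3ccc(F)c(Cl)c3)ccc2F)C1`) gives 8700 nM, compound 2 (`O=C(Nc1ccc(F)c(Cl)c1)c1ccc(F)c(S(=O)(=O)N2CCCC(O)CC2)c1`) gives 29000 nM and compound 3 (`CN1CCN(S(=O)(=O)c2cc(C(=O)Nc3ccc(F)c(Cl)c3)ccc2F)CC(O)C1`) gives 31000 nM. Compound 3 thus stands level with compound 2 and beyond the scatter from compound 1. Compound 4 (`O=C(Nc1ccc(F)c(Cl)c1)c1ccc(F)c(S(=O)(=O)N2CCOC[C@@H](O)C2)c1`) carries 6-hydroxy-1,4-oxazepan-4-yl in place of 6-hydroxy-4-methyl-1,4-diazepan-1-yl on a sulfonyl sulfur. Two modest steps start from the methoxy ring of compound 1: a 3.3-fold higher number from compound 1 to compound 2 (0.52 log units; beyond the scatter) and a 3.6-fold higher number from compound 1 to compound 3 (0.55 log units; beyond the scatter). Between the two hydroxy rings, the step is small: a 1.1-fold higher number from compound 2 to compound 3 (0.03 log units; within the scatter). Compound 4 also has a hydroxy ring, so no step beyond the scatter is expected, only a 1.3-fold lower number from compound 3 to compound 4 (0.11 log units; within the scatter). Compound 4 is estimated at 24000 nM, with an expected range of 10000 nM to 50000 nM.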

Compound 4, half-maximal cytotoxic concentration: 14000 nM
Estimate against measurement, compound 4: 1.7-fold (0.23 log units) above; the range from low to high includes it.
By their numbers in this assay, from the lowest: compounds 1 and 4 (each within the scatter of the next); then compounds 2 and 3 (each within the scatter of the next).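

In this assay, a hydroxy ring on the sulfonyl sulfur does not by itself bring the higher numbers: 6-hydroxy-1,4-oxazepan-4-yl gives a 2.2-fold lower number from compound 3 to compound 4 (0.35 log units; beyond the scatter) and a 2.1-fold lower number from compound 2 to compound 4 (0.32 log units; beyond the scatter) despite keeping the hydroxy. Going from the methoxy to the hydroxy form of this ring gives only a 1.6-fold higher number from compound 1 to compound 4 (0.21 log units; within the scatter) and does not separate the two. Nothing available here explains these differences. Still open, from the compounds shown here alone, are how the mirror-image form of compound 4 would compare, and whether an amine or a carboxylic acid in place of the ring's hydroxy would shift the number.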